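Methyl on the Oxime Oxygen: Compound 1 to Compound 3

The source may report more compounds than this note shows. Statements on the series, on what has been measured and on what is new or still open speak of the compounds shown alone.

Compound 1 `O/N=C(\CCN1CCN(c2ccccn2)CC1)c1ccccc1Cl` and compound 2 `O/N=C(\CCN1CCN(c2ccccn2)CC1)c1ccc(F)cc1` differ only in a 4-fluorophenyl in place of a 2-chlorophenyl on a carbon with a double bond to nitrogen. In a functional assay on HEK293 cells with D(4) dopamine receptor (Homo sapiens) as the target, read by FLIPR (on this read-out higher numbers stand for larger maximal responses and lower numbers for smaller maximal responses), compound 1 gives 74%, and compound 2 gives 74%; the step of no change at the digits printed from compound 1 to compound 2 (within the scatter) lies within the scatter, so compound 1 stands level with compound 2. Compound 3 `CO/N=C(\CCN1CCN(c2ccccn2)CC1)c1ccccc1Cl` differs from compound 1 by methyl in place of hydrogen on an oxygen. Going by the values given here, no measured step touches this oxygen, so the single known step offers no guidance. Compound 3 is therefore expected to keep a similar maximal response, an expected step of a number 2 percentage points lower from compound 1 to compound 3 (within the scatter). The efficacy of compound 3 is estimated at 72%, between 55% and 90%.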

Compound 3, largest response reached (reported as efficacy), in percent of the reference or control that the assay uses: 79%
For compound 3 the middle estimate is 7 percentage points below the measured one, within the range that was stated.
By their numbers in this assay, from the lowest: compounds 1, 2 and 3 (each within the scatter of the next).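

Methyl in place of hydrogen on the oxygen, read as hydroxy to methoxy, is the only change at this oxygen among the compounds shown, and in this assay it gives a number 5 percentage points higher from compound 1 to compound 3 (within the scatter). The hydroxy hydrogen can therefore be replaced by methyl without a step beyond the scatter in maximal response, at least with the 2-chlorophenyl group present. No available evidence bears on this result. On these data alone, whether an ethyl or benzyl group on the same oxygen gives a similar maximal response remains open, as does the effect of methyl on the oxygen of compound 2.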